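Swapping the aryl on the ring nitrogen: compound 3 to compound 4

A few compounds are considered here, and "the series" means these few. Any claim that something is new, unique, unknown or untested is made for them only; others in the source may bear on it.

Three spiro compounds have been tested in a functional assay on A549 cells (Homo sapiens) for antiproliferative activity, read by CCK-8 assay, with a stated time of 72 h; on this read-out lower numbers stand for stronger inhibition and higher numbers for weaker inhibition. Compound 1 `CC1=NN(c2ccc(Br)cc2)C(=O)C12C=CC(=O)C=C2c1cccc(C)c1` gives 45400 nM, and compound 2 `CC1=NN(c2ccc(C)cc2)C(=O)C12C=CC(=O)C=C2c1ccc(C)cc1` gives 37000 nM. For the measured compounds named here, compound 3 `CC1=NN(c2cccc(Cl)c2)C(=O)C12C=CC(=O)C=C2c1ccc(C)cc1` gives 9050 nM and thus stands with the lowest number of the three, its gap to compound 2 and its larger gap to compound 1 both being beyond the scatter; on these numbers it is the most potent compound so far.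

Compound 4 `CC1=NN(c2ccc(Br)cc2)C(=O)C12C=CC(=O)C=C2c1ccc(C)cc1` has not yet been measured. It differs from compound 3 in one place: 4-bromophenyl in place of 3-chlorophenyl on an amide-type nitrogen in a ring. Going by the values given here, the one measured step that bears on this site is the change a 4.1-fold lower number from compound 2 to compound 3 (0.61 log units; beyond the scatter), where a 3-chlorophenyl replaced a 4-methylphenyl on the same ring nitrogen. Compound 4 undoes that 3-chlorophenyl in favour of a 4-bromophenyl, a group that compound 1 already carries, with compound 1 sitting near compound 2 rather than near compound 3. The account therefore expects the number for compound 4 to rise back toward those of compounds 1 and 2, with a step of a 3.9-fold higher number from compound 3 to compound 4 (0.59 log units; beyond the scatter) in this assay. The estimate for compound 4 is 35000 nM, within a range from 12000 nM to 80000 nM.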

Compound 4, half-maximal inhibitory concentration: 27400 nM
Compound 4: the middle estimate sits 1.3-fold (0.11 log units) above what was measured; low and high end bracket the measured number.
By their numbers in this assay, from the lowest: compound 3; then compounds 4, 2 and 1 (each within the scatter of the next).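

In this assay the new result gives a direct comparison of two halogen-bearing aryl groups on the amide-type nitrogen, with the rest of the core unchanged: 4-bromophenyl in place of 3-chlorophenyl gives a clear loss (a 3.0-fold higher number from compound 3 to compound 4 (0.48 log units; beyond the scatter)). Bromo in place of methyl on that aryl group makes no readable difference (a 1.4-fold lower number from compound 2 to compound 4 (0.13 log units; within the scatter)), and neither does 4-methylphenyl in place of 3-methylphenyl on the double-bonded ring carbon (a 1.7-fold lower number from compound 1 to compound 4 (0.22 log units; within the scatter)), so among these four compounds only compound 3, the sole carrier of 3-chlorophenyl, stands apart. Nothing measured here accounts for any of these steps.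

The step from 3-chlorophenyl to 4-bromophenyl changes both the halogen and where it sits on the aryl group, so the compounds shown cannot say which of the two changes goes with the higher number; 4-chlorophenyl and 3-bromophenyl on the same nitrogen would separate them. Also open, on these data alone, is whether the lower number of compound 3 would hold with a different group at that place on the aryl ring, such as an amine or a carboxylic acid.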